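The source may report more compounds than this note shows. Statements on the series, on what has been measured and on what is new or still open speak of the compounds shown alone.

Working notes on the series.

Compound 1, `Cc1cc(NCCN2CCN(C)CC2)nc2ccc(NC(=O)c3ccc(Cl)c(Cl)c3)cc12`, is the reference point. In a functional assay on MCF7 cells (Homo sapiens) for antiproliferative activity, read by MTT assay, with a stated time of 72 h (a higher number here means a weaker inhibitor, a lower number a stronger inhibitor), compound 1 gives 1700 nM, the lowest of the two numbers available. Its nearest neighbour is compound 2, `CCN1CCN(c2cc(C)c3cc(NC(=O)c4cccc(Br)c4)ccc3n2)CC1`, which in this assay gives 11600 nM, a gap beyond the scatter. Compound 3, `CCN1CCN(c2cc(C)c3cc(NC(=O)c4ccccc4Cl)ccc3n2)CC1`, gives only a limit in this assay, > 50000 nM. That limit is the one described in the limit of > 50000 nM in this assay, at which 1 of the 3 values shown sits.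

The one measured step that connects two of these compounds is an at least 4.3-fold higher number from compound 2 to compound 3 (0.63 log units; beyond the scatter), a change on the carbonyl side of the shared core. It does not touch the part of the core that is varied next.

Compound 4, `Cc1cc(N2CCCC2)nc2ccc(NC(=O)c3ccc(Cl)c(Cl)c3)cc12`, is the next entry to be measured. The change from compound 1 is pyrrolidin-1-yl in place of (2-(4-methylpiperazin-1-yl)ethyl)amino on an aromatic carbon. Going by the values given here, no measured step in the set alters this position, so the step has no precedent among the three numbers. Compound 1 sits at the favourable end of the two values, and the untested change is given a wide margin: compound 4 is expected to fall near 4000 nM in this assay, within 900 nM to 20000 nM, which corresponds to an expected step of a 2.4-fold higher number from compound 1 to compound 4 (0.37 log units; beyond the scatter).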

Compound 4, half-maximal inhibitory concentration: 26300 nM
Beside the measured number, compound 4's estimate is 6.6-fold (0.82 log units) below it, and the stated range ends below it.
By their numbers in this assay, from the lowest: compound 1; then compound 2; then compound 4. At a limit, above all of these: compound 3.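

In this assay, going by these compounds alone, the position next to the ring nitrogen proves sensitive: a 15-fold higher number from compound 1 to compound 4 (1.19 log units; beyond the scatter) is the only measured step here, whereas the one earlier step, an at least 4.3-fold higher number from compound 2 to compound 3 (0.63 log units; beyond the scatter), lay on the carbonyl side of the shared core. With the carbonyl side held constant, the number therefore also responds to the group on this aromatic carbon, and pyrrolidin-1-yl is much less favourable here than (2-(4-methylpiperazin-1-yl)ethyl)amino. This single change swaps 10 heavy atoms for 5, and removes the six-membered ring with 2 hetero atoms and the hydrogen-bond donor all at once, while nothing in the data accounts for the size of the step.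

Which of these features carries the difference remains open, since the two compounds alter them together and compounds 2 and 3 differ from compounds 1 and 4 in more than one place. A (2-(dimethylamino)ethyl)amino chain or a morpholine ring at this position, on the carbonyl side of compound 1, would begin to separate the chain, the ring and the amine hydrogen.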